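The compounds below may be only part of what the source reports. "The series", "measured", "known", "first", "only" and "open" are said of these compounds alone.

Measured in an ADME assay on MT4 cells (Homo sapiens) for cytotoxicity; a lower number here means that less compound is tolerated, a higher number that more compound is tolerated:
compound 1, `O=C(CSc1snnc1-c1ccccc1)Nc1ccccc1[N+](=O)[O-]`: >= 246000 nM
compound 2, `O=C(CSc1snnc1-c1ccc(Cl)cc1Cl)Nc1ccccc1Br`: >= 146000 nM
compound 3, `O=C(CSc1snnc1-c1ccc(Cl)cc1Cl)Nc1ccccc1F`: 19500 nM

The value of compound 1 is a limit of this assay, not a number (the limit of >= 246000 nM in this assay, at which 1 of the 3 values shown sits). The value of compound 2 is likewise a limit (the limit of >= 146000 nM in this assay, at which 1 of the 3 values shown sits). Compound 3 is thus the only one of the three with a number; in this assay compound 3 gives 19500 nM. Among the compounds with values here, the single computed step among the measured compounds is an at least 7.4-fold lower number from compound 2 to compound 3 (0.87 log units; beyond the scatter).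

Compound 4, `O=C(CSc1snnc1-c1ccc(Cl)cc1Cl)Nc1ccccc1[N+](=O)[O-]`, is not yet measured in this assay. It differs from compound 3 in one place: nitro in place of fluoro on an aromatic carbon. Within the data shown here, no measured step exchanges fluoro for nitro, so the bearing of the one known step is indirect: it shows that the fluoro compound is the one that falls within the numeric window. Among the measured compounds shown here, compound 1 carries a nitro group on an unsubstituted phenyl and sits at a limit; no step to compound 4 is computed for that pair. An upward step is expected, a 5.1-fold higher number from compound 3 to compound 4 (0.71 log units; beyond the scatter), with a fair chance that only a limit is reported. Compound 4 is estimated at 100000 nM, range 25000 nM to 300000 nM.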

Compound 4, half-maximal cytotoxic concentration: > 283000 nM
Compound 4: only a limit was reported; the forecaster's own chance of this, stated with the estimate: 50%; middle value at least 2.8-fold (0.45 log units) from the limit.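

In this assay, within the data shown here, nitro in place of fluoro at this position gives an at least 14-fold higher number from compound 3 to compound 4 (1.16 log units; beyond the scatter), the first measured step for this exchange. Compound 4 is reported only as a limit, > 283000 nM. With the 2,4-dichlorophenyl group held fixed, bromo and nitro both end at limits and only fluoro gives a number, while the steps from compound 2 and from compound 1 to compound 4 cannot be read, each joining two limits.

From the compounds shown here alone, how far the true value of compound 4 lies from its limit stays open, as does whether the fluoro to nitro step would hold on the unsubstituted phenyl of compound 1. Also open, going by these compounds, is whether an amine or a carboxylic acid at this position would give a number, as fluoro does, or a limit, as bromo and nitro do.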